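Ethyl in Place of Phenyl on the Ring Nitrogen

This account rests on a few compounds, and the source may have more. Where it says the series, first, only, none or still open, it means among the compounds named here.

Compound 1 `COc1ccc(-c2nnc(SC/C(=N/O)c3ccccc3)n2-c2ccccc2)cc1` gives 80% in a functional assay on the whole organism (strain albino) for inhibition, with Rattus norvegicus as the target, read by paw edema, with a stated time of 4 h, at a dose of 0.28 mmol/kg by the oral route (on this read-out lower numbers stand for less inhibition and higher numbers for more inhibition at the one dose given (going by the name of the read-out)), the second highest of the three numbers measured. Compound 2 `COc1ccc(-c2nnc(SC/C(=N/O)c3ccccc3)n2-c2ccccc2)cc1OC` gives 81%, and the step of a number 1 percentage points higher from compound 1 to compound 2 (within the scatter) stays within the scatter. Compound 3 `COc1ccc(-c2nnc(SCC(=O)c3ccccc3)n2-c2ccccc2)cc1` gives 68%, the step of a number 12 percentage points lower from compound 1 to compound 3 (beyond the scatter) being the only one beyond the scatter. Compound 4 `CCn1c(SC/C(=N/O)c2ccccc2)nnc1-c1ccc(OC)cc1` differs from compound 1 in one place: ethyl in place of phenyl on an aromatic nitrogen. Going by the values given here, neither measured step touches the aromatic nitrogen, so there is no direct precedent; the two steps that exist show one change that stayed within the scatter and one modest loss, and a step in the expected range of the scatter seems most likely. Compound 4 is therefore expected to give 75%, with a range from 60% to 88%. The expected step is a number 5 percentage points lower from compound 1 to compound 4 (within the scatter).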

Compound 4, a percentage reported as inhibition, in the whole organism at one dose (the size of the read-out at that dose, not a potency): 78%
For compound 4 the middle estimate is 3 percentage points below the measured one; the range from low to high includes it.
By their numbers in this assay, from the lowest: compounds 3, 4, 1 and 2 (each within the scatter of the next, the first and the last beyond it).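

The step at the aromatic nitrogen is a number 2 percentage points lower from compound 1 to compound 4 (within the scatter) in this assay, so phenyl at this position can give way to ethyl, a far smaller group with no ring, without a change beyond the scatter. Going by these compounds alone, this is the only reading at this position, and it shows that a ring on this nitrogen is not needed to keep the inhibition of compound 1 at the one dose given. No measurement on hand explains why the two groups read alike. As far as these compounds go, whether a longer chain such as butyl, a benzyl group or a chain ending in an amine would fit this nitrogen equally well stays open. Also open, from the compounds shown here alone, is whether ethyl would read the same with the ketone of compound 3 in place of the oxime.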